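The source may report more compounds than this note shows. Statements on the series, on what has been measured and on what is new or still open speak of the compounds shown alone.

Compound 1 `O=S(=O)(Nc1ccc(-c2nc3ccccc3o2)cc1)c1cccc(F)c1`, compound 2 `O=S(=O)(Nc1ccc(-c2nc3ccccc3o2)cc1)c1ccccc1Cl` and compound 3 `O=S(=O)(Nc1ccc2oc(-c3ccccc3)nc2c1)c1cccc(F)c1` are the measured members of the series.
In an ADME assay on HEK293 cells (Homo sapiens) for cytotoxicity, read by resazurin assay, with a stated time of 48 h (a lower number here means that less compound is tolerated, a higher number that more compound is tolerated), compound 1 gives > 100000 nM, which is a limit of the assay and not a number.
In this assay compound 2 gives > 100000 nM, again a limit of the assay.
In this assay compound 3 gives 68000 nM.

Compound 3 therefore stands as the only number shown; the other two values are limits, as the limit of > 100000 nM in this assay, at which 2 of the 3 values shown sit, records. Going by the values given here, the one step measured so far, a step that the two limits leave unreadable from compound 1 to compound 2, is left unreadable by the two limits, so nothing is known of its size.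

Compound 4 `COc1ccc(Cl)cc1S(=O)(=O)Nc1ccc2oc(-c3ccccc3)nc2c1` has not yet been measured. It differs from compound 3 by 5-chloro-2-methoxyphenyl in place of 3-fluorophenyl on a sulfonyl sulfur. Among the compounds with values here, no measured step bears directly on this change: the only step available exchanges one substituted phenyl for another on the same sulfonyl sulfur and cannot be read. Within the data shown here, with the limit of > 100000 nM in this assay, at which 2 of the 3 values shown sit, showing two of three values at the limit and compound 3 the only number, no step beyond the scatter is expected in this assay in either direction, and the estimated step of a 1.0-fold higher number from compound 3 to compound 4 (0.01 log units; within the scatter) is accordingly kept small. Compound 4 is expected to give 70000 nM, in the range 30000 nM to 150000 nM.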

Compound 4, half-maximal cytotoxic concentration: 74000 nM
Compound 4: middle estimate off by 1.1-fold (0.02 log units), on the low side; measured number inside the range.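

Going by these compounds alone, the exchange of 3-fluorophenyl for 5-chloro-2-methoxyphenyl on a sulfonyl sulfur gives the first readable step at this position in this assay: a 1.1-fold higher number from compound 3 to compound 4 (0.04 log units; within the scatter). The entering group carries a chlorine and a hydrogen-bond acceptor that the leaving group lacks, yet on the core of compound 3 this exchange does not separate the two compounds in this read-out, so this position tolerates at least this one exchange of substituted phenyl groups without a step beyond the scatter. The only earlier step at this sulfur, on the core of compound 1, cannot be read, so this pair of numbers is the sole readable evidence on the position, and the limits remain a constraint on the series: the limit of > 100000 nM in this assay, at which 2 of the 4 values shown sit.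

Going by these compounds, whether a group of a different kind on the sulfonyl sulfur, such as a phenyl bearing an amine or a carboxylic acid, or a longer alkyl chain in place of the phenyl, would give a step beyond the scatter remains open. Also open is how the core of compound 1 relates to the core of compound 3, since the compounds shown give no readable step between the two.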